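Swapping a pyrrolidinyl ring for a pentafluoroethyl group

The compounds below may be only part of what the source reports. "The series", "measured", "known", "first", "only" and "open" are said of these compounds alone.

Of the compounds shown here, two have been measured in an ADME assay on microsomes from liver (Rattus norvegicus, strain Sprague-Dawley) for metabolic stability, read by HPLC, using NADPH, with stated times of 5 min and 60 min, tested at 10 uM; on this read-out higher numbers stand for fast clearance and lower numbers for slow clearance. Compound 1, `CC(C)(C)c1ccc(C(=O)NCc2ccc(NS(=O)(=O)C3CC3)cc2Cl)cc1`, gives 41 mL.min-1.g-1 in this assay. Compound 2, `CS(=O)(=O)Nc1ccc(CNC(=O)c2ccc(N3CCCC3)cc2)c(Cl)c1`, gives 17 mL.min-1.g-1, the lower of the two numbers; the gap from compound 1 to compound 2 is beyond the usual scatter, so compound 2 is cleared more slowly.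

The next compound, compound 3, `CS(=O)(=O)Nc1ccc(CNC(=O)c2ccc(C(F)(F)C(F)(F)F)cc2)c(Cl)c1`, has not yet been measured. Its structure differs from compound 2 in one place: 1,1,2,2,2-pentafluoroethyl in place of pyrrolidin-1-yl on an aromatic carbon. The change puts a fluorinated two-carbon chain on an aromatic carbon where compound 2 carries a five-membered ring with one nitrogen.

Among the compounds with values here, with no measured pair showing this exact swap, the expectation rests mainly on compound 2 and its value 17 mL.min-1.g-1. The step from compound 2 to compound 3 is expected to be small and downward, a 1.4-fold lower number from compound 2 to compound 3 (0.15 log units; within the scatter), probably within the scatter. Compound 3 is therefore estimated at 12 mL.min-1.g-1 in this assay, within a range from 5 mL.min-1.g-1 to 30 mL.min-1.g-1.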

Compound 3, intrinsic clearance in microsomes: 14 mL.min-1.g-1
Compound 3: middle estimate off by 1.2-fold (0.07 log units), on the low side; measured number inside the range.
By their numbers in this assay, from the lowest: compounds 3 and 2 (each within the scatter of the next); then compound 1.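

In this assay, 1,1,2,2,2-pentafluoroethyl in place of pyrrolidin-1-yl gives a 1.2-fold lower number from compound 2 to compound 3 (0.08 log units; within the scatter) and so leaves compound 2 and compound 3 indistinguishable on this read-out. At this place, on an aromatic carbon para to a large group, a fluorinated two-carbon chain with no ring and no nitrogen reads the same as a five-membered non-aromatic ring with one nitrogen, so for this pair of groups neither the ring nor its nitrogen is needed to keep the number where it is. Nothing measured here explains why the two groups read alike.

On these data alone, whether a small open-chain amine such as dimethylamino would read the same at this place remains open. So does the outcome for a carboxylic acid there.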